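This account rests on a few compounds, and the source may have more. Where it says the series, first, only, none or still open, it means among the compounds named here.

In a functional assay on HepG2 cells (Homo sapiens) for antiproliferative activity, read by MTT assay, with a stated time of 48 h (a higher number here means a weaker inhibitor of growth, a lower number a stronger inhibitor of growth), compound 1 (`CCCOC(=O)N1N=C(c2ccccc2)CC1c1cc(OC)c(OC)c(OC)c1`) gives > 10000 nM, which is a limit and not a number. Compound 2 (`CCCOC(=O)N1N=C(c2ccc(OC)cc2)CC1c1cc(OC)c(OC)c(OC)c1`) gives > 10000 nM, also a limit. Within the data shown here, compound 3 (`CCOC(=O)N1N=C(c2cccc(O)c2)CC1c1cc(OC)c(OC)c(OC)c1`) gives 1790 nM, the only actual number in the set. The other two values stand at the limit of > 10000 nM in this assay, at which 2 of the 3 values shown sit.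

Compound 4 (`CCCOC(=O)N1N=C(c2cccc(O)c2)CC1c1cc(OC)c(OC)c(OC)c1`) differs from compound 3 by a single change: methyl in place of hydrogen on a saturated chain carbon, two bonds along the chain from an oxygen next to a carbonyl group. Put simply, ethoxy becomes propoxy. Among the measured compounds shown here, the one measured step, a step that the two limits leave unreadable from compound 1 to compound 2, concerns methoxy in place of hydrogen on an aromatic carbon, so it gives no size for this change. Compound 1 and compound 2 share the propoxy group of compound 4 but differ from it elsewhere, which makes them a weak warning only. The expectation therefore starts from compound 3 at 1790 nM, with a slight lean towards weaker growth inhibition in this assay and probably no step beyond the scatter. The estimate is an expected 1.6-fold higher number from compound 3 to compound 4 (0.19 log units; within the scatter). For compound 4 the expected value is 2800 nM, with an estimated range from 900 nM to 9000 nM.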

Compound 4, concentration for 50% growth inhibition: > 10000 nM
Compound 4: only a limit was reported (the forecaster's own chance of this, stated with the estimate: 20%); at least 3.5-fold (0.55 log units) between middle value and limit.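

In this assay, with the 3-hydroxyphenyl group held fixed, ethoxy to propoxy is a change whose size can be read, and one added methyl is enough to give a step beyond the scatter (an at least 5.5-fold higher number from compound 3 to compound 4 (0.74 log units; beyond the scatter)). The earlier compounds shown here gave no size for any change on a saturated chain carbon, two bonds along the chain from an oxygen next to a carbonyl group, and this single pair now does. Compound 4 gives only a limit, which it shares with compound 1 and compound 2, so the steps among these three cannot be read: (the limit of > 10000 nM in this assay, at which 3 of the 4 values shown sit).

On these data alone, how a butoxy chain or a branched isopropoxy group would behave at this place stays open. So does whether an ethoxy group would give a measurable number with the phenyl or 4-methoxyphenyl group of compound 1 and compound 2.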